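Amino on the methoxybenzyl ring of compound 1

The source may hold more compounds than are shown below. What is called first, only, known or untested is meant among the compounds shown, and "the series" means these compounds.

Compound 1 `COc1ccc(CN(C(=O)CSC(=S)N2CCN(C(=O)OC(C)(C)C)CC2)c2cc(OC)c(OC)c(OC)c2)cc1` is the anchor of this set. In a functional assay on MGC-803 cells (Homo sapiens) for inhibition, read by CCK-8 assay, with a stated time of 48 h (a lower number here means a stronger inhibitor, a higher number a weaker inhibitor), compound 1 gives 310 nM, the lowest of the two numbers recorded. Compound 2 `COc1ccc(CN(C(=O)CSC(=S)N2CCN(Cc3ccc(C(C)(C)C)cc3)CC2)c2cc(OC)c(OC)c(OC)c2)cc1` gives 5390 nM in this assay. Compound 3 `COc1ccc(CN(C(=O)CSC(=S)N2CCN(C(=O)OC(C)(C)C)CC2)c2ccccc2)cc1` reaches only the limit of > 20000 nM in this assay, so no number is known for it (the limit of > 20000 nM in this assay, at which 1 of the 3 values shown sits).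

Two single-point steps have been measured. Putting 4-(tert-butyl)benzyl in place of tert-butoxycarbonyl on the amine nitrogen in the ring gives a 17-fold higher number from compound 1 to compound 2 (1.24 log units; beyond the scatter). Putting phenyl in place of 3,4,5-trimethoxyphenyl on the amide-type nitrogen gives an at least 64-fold higher number from compound 1 to compound 3 (1.80 log units; beyond the scatter).

Compound 4 `COc1ccc(CN(C(=O)CSC(=S)N2CCN(C(=O)OC(C)(C)C)CC2)c2cc(OC)c(OC)c(OC)c2)cc1N` differs from compound 1 by amino in place of hydrogen on an aromatic carbon. Neither measured step touches the 4-methoxybenzyl part of the shared core, so neither bears directly on this change; the two measured steps only show that the ring amine substituent and the trimethoxyphenyl group are each sensitive positions. The added group is a single nitrogen, and with nothing known for that position the expectation is a step of a 1.3-fold higher number from compound 1 to compound 4 (0.11 log units; within the scatter), within the scatter or at most a modest move in either direction. Compound 4 is therefore estimated at 400 nM in this assay, with a range of 150 nM to 1500 nM.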

Compound 4, half-maximal inhibitory concentration: 184 nM
Beside the measured number, compound 4's estimate is 2.2-fold (0.34 log units) above it; low and high end bracket the measured number.
By their numbers in this assay, from the lowest: compounds 4 and 1 (each within the scatter of the next); then compound 2. At a limit, above all of these: compound 3.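

In this assay, amino in place of hydrogen on the aromatic carbon ortho to a methoxy group gives a 1.7-fold lower number from compound 1 to compound 4 (0.23 log units; within the scatter), the first reading from the 4-methoxybenzyl part of the shared core. Unlike the steps at the ring amine substituent and at the trimethoxyphenyl group, both beyond the scatter, this change leaves compound 4 level with compound 1, so this carbon accepts an amino group with no measurable cost in this cell assay. Nothing in the data shown accounts for this step, so the amino group can be credited with neither a contribution nor a lack of one.

Going by these compounds, whether this position tolerates substitution in general or accepts amino in particular stays open, and a hydroxyl, an acetamide or a dimethylamino group on the same carbon would separate those two readings. It is also open whether the 3-amino-4-methoxybenzyl group behaves the same way when 4-(tert-butyl)benzyl replaces tert-butoxycarbonyl on the ring amine, as that pairing lies outside the compounds shown.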